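Cytotoxicity notes on compounds 1 to 4

The source may report more compounds than this note shows. Statements on the series, on what has been measured and on what is new or still open speak of the compounds shown alone.

Three members of the shared core have been run in an ADME assay on cells (Homo sapiens) for cytotoxicity, read by resazurin assay, with a stated time of 5 days; on this read-out higher numbers stand for lower toxicity in this test and lower numbers for higher toxicity in this test. Compound 1 `COc1ccc(-c2nc(CSc3cc(C)cc(C)c3)nc3ccsc23)cn1` carries 3,5-dimethylphenyl on the sulfur. In this assay compound 1 gives > 50000 nM, which is a limit of the assay and not a number. Compound 2 `COc1ccc(-c2nc(CSc3cccc(Cl)c3)nc3ccsc23)cn1` carries 3-chlorophenyl on the sulfur. In this assay compound 2 gives > 10000 nM, again a limit. Compound 3 `COc1ccc(-c2nc(CSCc3cccc(Cl)c3)nc3ccsc23)cn1` carries 3-chlorobenzyl on the sulfur. In this assay compound 3 gives > 50000 nM, also a limit.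

Compound 3 therefore stands at a limit only, and the two other values shown are limits as well: the limit of > 50000 nM in this assay, at which 2 of the 3 values shown sit, and (the limit of > 10000 nM in this assay, at which 1 of the 3 values shown sits). The three steps are accordingly a step that the two limits leave unreadable from compound 1 to compound 2, a step that the two limits leave unreadable from compound 1 to compound 3 and a step that the two limits leave unreadable from compound 2 to compound 3.

Compound 4 `COc1ccc(-c2nc(CSc3cc(Cl)ccc3Cl)nc3ccsc23)cn1` differs from compound 3 by 2,5-dichlorophenyl in place of 3-chlorobenzyl on a sulfur. Going by the values given here, none of the measured steps gives a readable size or direction, so no step beyond the scatter can be anticipated from them. Compound 4 is estimated at 50000 nM. For compound 4 the expected range runs from 15000 nM to 150000 nM. The expected step of a number no higher from compound 3 to compound 4 (the limit leaves the size open) is taken to lie within the scatter, and a limit rather than a number is the most likely outcome.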

Compound 4, half-maximal cytotoxic concentration: > 50000 nM
Compound 4 ended at the assay's limit (the forecaster's own chance of this, stated with the estimate: 80%); the middle value sits exactly at the limit.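

Compound 4 stands at a limit in this assay, as do compound 1, compound 2 and compound 3, and none of the steps linking compound 4 to these three can be read. The compounds shown leave open at what concentration any of them turns cytotoxic, and whether the groups on the sulfur differ at all on this read-out.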